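The source may report more compounds than this note shows. Statements on the series, on what has been measured and on what is new or still open speak of the compounds shown alone.

Compound 2 `COc1cc(-c2nn(-c3cccc(NC(=O)c4ccc(Cl)c(C(F)(F)F)c4)c3)cc2-c2ccncc2)ccc1Cl` stands only at a limit in a functional assay on KM12 cells (Homo sapiens) for inhibition, read by sulforhodamine B assay, with a stated time of 48 h; a higher number here means that more compound is tolerated, a lower number that less compound is tolerated: compound 2 gives > 32500 nM, which is a limit of the assay and not a number. Compound 1 `COc1cc(-c2nn(-c3cccc(NC(=O)Nc4cccc(C(F)(F)F)c4)c3)cc2-c2ccncc2)ccc1Cl` likewise reaches only a limit, giving > 50000 nM in this assay. The step that the two limits leave unreadable from compound 1 to compound 2 is therefore unreadable, since the limit of > 32500 nM in this assay, at which 1 of the 2 values shown sits, and the limit of > 50000 nM in this assay, at which 1 of the 2 values shown sits, both mark limits. Compound 3 `COc1cc(-c2nn(-c3cccc(NC(=O)Nc4ccc(Cl)c(C(F)(F)F)c4)c3)cc2-c2ccncc2)ccc1Cl` differs from compound 2 by (4-chloro-3-(trifluoromethyl)phenyl)amino in place of 4-chloro-3-(trifluoromethyl)phenyl on a carbonyl carbon. Among the compounds with values here, no measured step bears readably on this change, so no direction beyond the scatter is expected. Compound 3 is expected near 60000 nM, within 20000 nM to 200000 nM, the expected step being a step that the limit leaves unreadable from compound 2 to compound 3.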

Compound 3, concentration lethal to 50% of the cells: 14900 nM
Compound 3: the middle estimate sits 4.0-fold (0.60 log units) above what was measured, outside the stated range (below it).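

On the carbonyl carbon, (4-chloro-3-(trifluoromethyl)phenyl)amino in place of 4-chloro-3-(trifluoromethyl)phenyl gives an at least 2.1-fold lower number from compound 2 to compound 3 (0.33 log units; beyond the scatter) in this assay. Chloro in place of hydrogen on an aromatic carbon gives an at least 3.3-fold lower number from compound 1 to compound 3 (0.52 log units; beyond the scatter). Each step thus shows that its change can matter in this series, though each starts from a compound standing at a limit, so neither full size can be read.

As far as these compounds go, whether the amide hydrogen of the entering group matters remains open. So does whether bromo or nitrile in place of chloro would give a similar step.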